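This account rests on a few compounds, and the source may have more. Where it says the series, first, only, none or still open, it means among the compounds named here.

Among the measured compounds shown here, in a functional assay on K562 cells (Homo sapiens) for cytotoxicity, in the presence of a further agent that is not named here (on this read-out lower numbers stand for stronger inhibition and higher numbers for weaker inhibition), two compounds have numbers so far. Compound 1 `Cc1cccc(-c2cc(-c3ccc(Cl)o3)cc(-c3ccsc3)n2)c1` gives 20200 nM, and compound 2 `Clc1ccc(-c2cc(-c3cccnc3)nc(-c3cccs3)c2)o1` gives 22300 nM. These two values lie within the usual scatter of each other, so compound 1 stands level with compound 2. For the measured compounds named here, the two compounds differ in more than one place, and no measured pair differs in only one, so the data show no single change to learn from.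

Compound 3 `Cc1ccc(-c2cc(-c3ccc(Cl)o3)cc(-c3ccsc3)n2)cc1` has not yet been measured. It keeps the core of compound 1 and changes one group: 4-methylphenyl in place of 3-methylphenyl on an aromatic carbon. The atoms stay the same and are only joined differently. Going by the values given here, with no measured step as a guide, no step beyond the scatter is expected, and neither direction is favoured. The estimated change is a 1.0-fold lower number from compound 1 to compound 3 (0.00 log units; within the scatter). The expected value for compound 3 is 20000 nM, within an estimated range of 8000 nM to 50000 nM.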

Compound 3, half-maximal inhibitory concentration: 19900 nM
For compound 3 the middle estimate is 1.0-fold (0.00 log units) above the measured one; low and high end bracket the measured number.
By their numbers in this assay, from the lowest: compounds 3, 1 and 2 (each within the scatter of the next).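

Among the compounds shown here, this is the first single change that can be read: in this assay, putting 4-methylphenyl in place of 3-methylphenyl on the aromatic carbon next to the ring nitrogen gives a 1.0-fold lower number from compound 1 to compound 3 (0.01 log units; within the scatter) with the same atoms joined differently. For this pair, then, moving the methyl group around the phenyl ring makes no difference that this read-out can separate from the scatter of repeated measurements. No measured evidence is at hand to explain this result.

Both groups are methyl-bearing phenyl rings, which leaves open what a different kind of group at this position would do, such as an amine, a carboxylic acid or a longer chain. For the compounds shown here, no single step yet touches the 5-chlorofuran-2-yl or thiophen-3-yl groups, and their part in the activity remains unknown.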